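Swapping fluoro for cyano on a weakly active chromone

The compounds below may be only part of what the source reports. "The series", "measured", "known", "first", "only" and "open" are said of these compounds alone.

Compound 1 `O=c1ccoc2cc(OCc3cn(Cc4cccc(F)c4)nn3)ccc12` was tested in a functional assay on MDA-MB-231 cells (Homo sapiens) for cytotoxicity, read by MTT assay, with a stated time of 48 h; on this read-out higher numbers stand for weaker inhibition and lower numbers for stronger inhibition. In this assay compound 1 gives > 100000 nM, which is a limit of the assay rather than a measured number. Two close relatives do give numbers. Compound 2 `O=c1ccoc2cc(OCc3cn(Cc4ccccc4Cl)nn3)ccc12` gives 15100 nM in this assay, and compound 3 `O=c1ccoc2cc(OCc3cn(Cc4ccccc4F)nn3)ccc12` gives 29800 nM. The step of an at least 6.6-fold lower number from compound 1 to compound 2 (0.82 log units; beyond the scatter) and the step of an at least 3.3-fold lower number from compound 1 to compound 3 (0.52 log units; beyond the scatter) show that placing 2-chlorophenyl or 2-fluorophenyl where compound 1 carries 3-fluorophenyl brings the number down from the limit. Between chloro and fluoro on that aromatic carbon the difference is small: a 2.0-fold higher number from compound 2 to compound 3 (0.30 log units; within the scatter). Compound 1 thus stands at the weak end of everything seen here, sitting at the limit (the limit of > 100000 nM in this assay, at which 1 of the 3 values shown sits).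

Compound 4 `N#Cc1cccc(Cn2cc(COc3ccc4c(=O)ccoc4c3)nn2)c1` keeps the shared core of compound 1 and differs in one place only: cyano in place of fluoro on an aromatic carbon. Among the measured compounds shown here, none of the measured steps tests a cyano group; the two that start from compound 1 exchange the whole substituted phenyl, and the third swaps one halogen for another. For the measured compounds named here, no step bears directly on this change, so there is no ground to expect a step beyond the scatter, and a number close to the limit of compound 1 seems most likely. Compound 4 is expected to give about 90000 nM, within a range from 25000 nM to 300000 nM, in this assay. That corresponds to an expected step of an at least 1.1-fold lower number from compound 1 to compound 4 (0.04 log units; that floor lies within the scatter).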

Compound 4, half-maximal inhibitory concentration: > 100000 nM
Compound 4: only a limit was reported (the forecaster's own chance of this, stated with the estimate: 50%); at least 1.1-fold (0.04 log units) between middle value and limit.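

Neither fluoro nor cyano on this aromatic carbon, meta to a large group, gives a readable number in this assay, so compound 4 adds a second substituent at this place that stays at the limit: the limit of > 100000 nM in this assay, at which 2 of the 4 values shown sit. The direct step from compound 1 to compound 4 cannot be read, and the other steps that end at a limit show only a minimum size, not a true one. Among the compounds shown here, compound 4 still stands clearly apart from the two compounds with a number, with an at least 3.3-fold higher number from compound 3 to compound 4 (0.52 log units; beyond the scatter) and an at least 6.6-fold higher number from compound 2 to compound 4 (0.82 log units; beyond the scatter), and among the four compounds only those carrying 2-fluorophenyl and 2-chlorophenyl give numbers, with no compound going against this split.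

As far as these compounds go, these last two steps change the group and its place together, which leaves open whether the difference comes from the place on the ring or from the group itself, and how far compound 1 and compound 4 lie from each other also remains unknown. Whether a methoxy group or an amine on this same aromatic carbon would bring the number down from the limit is open as well.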